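Compound 2 to compound 4: bromo in place of methyl

A few compounds are considered here, and "the series" means these few. Any claim that something is new, unique, unknown or untested is made for them only; others in the source may bear on it.

Among the compounds with values here, in a functional assay on KYSE-450 cells (Homo sapiens) for inhibition, read by MTT assay, with a stated time of 48 h (on this read-out higher numbers stand for weaker inhibition and lower numbers for stronger inhibition), compound 2 `CC/C=C/C(=O)N(Cc1ccc(OC)c(O)c1)c1cc(OC)c(OC)c(OC)c1` gives 72 nM, the lowest number of the three measured so far. Compound 1 `C#CC(=O)N(Cc1ccc(OC)c(O)c1)c1cc(OC)c(OC)c(OC)c1` gives 570 nM, and compound 3 `COc1ccc(CNc2cc(OC)c(OC)c(OC)c2)cc1F` gives 46200 nM.

The next compound to be read, compound 4 `COc1ccc(CN(C(=O)/C=C/CBr)c2cc(OC)c(OC)c(OC)c2)cc1O`, differs from compound 2 in one place: bromo in place of methyl on a saturated chain carbon bound to a double-bonded chain carbon. This is bromo in place of methyl on a saturated chain carbon bound to a double-bonded chain carbon, or ethyl to bromomethyl when cut one bond further out.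

Within the data shown here, only one measured step bears on this change: a 7.9-fold lower number from compound 1 to compound 2 (0.90 log units; beyond the scatter), with but-1-en-1-yl in place of ethynyl on a carbonyl carbon. That modest step lies beyond the scatter and shows that the group on this carbonyl can move the number in this assay. Among the measured compounds shown here, no measured step exchanges methyl for bromo, so the data give no direction for this change, and no shift beyond the scatter is expected. The estimated step is a 1.2-fold lower number from compound 2 to compound 4 (0.08 log units; within the scatter). Compound 4 is expected at 60 nM, with an estimated range of 15 nM to 250 nM.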

Compound 4, half-maximal inhibitory concentration: 100 nM
The estimate for compound 4 lay 1.7-fold (0.22 log units) below the measured number; the measured number falls inside the stated range.
By their numbers in this assay, from the lowest: compounds 2 and 4 (each within the scatter of the next); then compound 1; then compound 3.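

In this assay, bromo in place of methyl on a saturated chain carbon bound to a double-bonded chain carbon gives a 1.4-fold higher number from compound 2 to compound 4 (0.14 log units; within the scatter), so the first exchange measured at this place leaves the two compounds within the scatter of each other. On the carbonyl carbon, 3-bromoprop-1-en-1-yl in place of ethynyl gives a 5.7-fold lower number from compound 1 to compound 4 (0.76 log units; beyond the scatter), which places a second group with a double bond apart from ethynyl, as but-1-en-1-yl already was. No evidence at hand accounts for either step.

Going by these compounds, only methyl and bromo have been compared on this saturated chain carbon, so the reach of the exchange remains open. A dimethylamino group, a hydroxyl or a longer chain at this place could still separate from compound 2 and compound 4 or stay with them.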